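The source may report more compounds than this note shows. Statements on the series, on what has been measured and on what is new or still open speak of the compounds shown alone.

Working notes on the series. In a functional assay for inhibition, read by fluorescence and spectrophotometry, with a stated time of 30 h (on this read-out higher numbers stand for weaker inhibition and lower numbers for stronger inhibition), compound 2 (`COc1ccc(-c2cc(=O)c3ccc(OCCCN4CCC(C)CC4)cc3o2)cc1`) gives 42600 nM. This sits within the scatter of compound 1 (`COc1ccc(-c2cc(=O)c3ccc(O)cc3o2)cc1OC`) at 47400 nM and of compound 3 (`COc1ccc(-c2cc(=O)c3ccc(OCCCCCCCN4CCC(C)CC4)cc3o2)cc1`) at 61600 nM, so compound 2 holds no distinct place among the three.

Compound 4 (`COc1ccc(-c2cc(=O)c3ccc(OCCCN4CCC(C)CC4)cc3o2)cc1OC`) keeps the side chain of compound 2 and differs from it as follows: methoxy in place of hydrogen on an aromatic carbon. In words, this is methoxy in place of hydrogen on an aromatic carbon, taking 4-methoxyphenyl to 3,4-dimethoxyphenyl.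

Going by the values given here, no measured step isolates this change. Among the compounds with values here, the only measured step, a 1.4-fold higher number from compound 2 to compound 3 (0.16 log units; within the scatter), alters the chain and not the aryl group, and it stays within the scatter. Compound 1 already carries 3,4-dimethoxyphenyl but lacks the 4-methylpiperidin-1-yl chain, so it differs from compound 2 elsewhere as well. Even so, compound 1 at 47400 nM gives no sign that 3,4-dimethoxyphenyl sets a number apart in this series.

No shift beyond the scatter is therefore expected in this assay, and no direction can be supported. The estimated step is a 1.1-fold higher number from compound 2 to compound 4 (0.03 log units; within the scatter). For compound 4 the expected value is 46000 nM, with an estimated range of 21000 nM to 95000 nM.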

Compound 4, half-maximal inhibitory concentration: 47700 nM
For compound 4 the middle estimate is 1.0-fold (0.02 log units) below the measured one; measured number inside the range.
By their numbers in this assay, from the lowest: compounds 2, 1, 4 and 3 (each within the scatter of the next).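

In this assay, methoxy in place of hydrogen on this aromatic carbon, ortho to a methoxy group, now has a step of its own, a 1.1-fold higher number from compound 2 to compound 4 (0.05 log units; within the scatter), so taking 4-methoxyphenyl to 3,4-dimethoxyphenyl on this side chain does not separate the two compounds. Going by these compounds alone, with 3,4-dimethoxyphenyl held constant, the side chain can also be read alone for the first time: 3-(4-methylpiperidin-1-yl)propyl in place of hydrogen on the oxygen gives a 1.0-fold higher number from compound 1 to compound 4 (0.00 log units; within the scatter), which also stays within the scatter. No supporting measurement is available to explain either step.

The compounds shown leave open whether a group other than methoxy on this aromatic carbon, such as hydroxy, chlorine or a carboxylic acid, would give a step beyond the scatter in this assay. They also leave open whether another amine at the end of the chain, such as morpholine or a primary amine, would separate from 4-methylpiperidin-1-yl, and whether 3,4-dimethoxyphenyl would stay within the scatter when paired with the longer chain of compound 3.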